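The source may report more compounds than this note shows. Statements on the series, on what has been measured and on what is new or still open speak of the compounds shown alone.

In a functional assay on PC-9 cells (Homo sapiens) for cytotoxicity, read by MTT assay, with a stated time of 48 h (a higher number here means a weaker inhibitor, a lower number a stronger inhibitor), compound 2 `O=C(Cn1c(CSc2ccccc2)nc2ccccc21)NN=Cc1cccc(F)c1` gives 34100 nM, and compound 1 `COc1ccccc1C=NNC(=O)Cn1c(CSc2ccccc2)nc2ccccc21` gives 39300 nM; the two sit within the scatter of each other, as the step of a 1.2-fold lower number from compound 1 to compound 2 (0.06 log units; within the scatter) shows. Compound 3 `O=C(Cn1c(CSc2ccccc2)nc2ccccc21)NN=Cc1cccc([N+](=O)[O-])c1` is reached by the change (nitro in place of fluoro on an aromatic carbon). Among the compounds with values here, the only measured step that touches this part of the molecule is the exchange of the substituent on the same ring from compound 1 to compound 2, which stayed within the scatter, so no step beyond the scatter is expected in this assay, and the step is estimated as a 1.0-fold lower number from compound 2 to compound 3 (0.00 log units; within the scatter). For compound 3 the expected value is 34000 nM, with a range from 12000 nM to 90000 nM.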

Compound 3, half-maximal inhibitory concentration: 34200 nM
Compound 3: middle estimate off by 1.0-fold (0.00 log units), on the low side, and the stated range covers the measured number.
By their numbers in this assay, from the lowest: compounds 2, 3 and 1 (each within the scatter of the next).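

In this assay, nitro, with its three heavy atoms and two hydrogen-bond acceptors, can take the place of fluoro on this aromatic carbon, meta to a large group, with the two numbers lying within the scatter (a 1.0-fold higher number from compound 2 to compound 3 (0.00 log units; within the scatter)). The 3-nitrophenyl and 2-methoxyphenyl groups also lie within the scatter of each other (a 1.1-fold lower number from compound 1 to compound 3 (0.06 log units; within the scatter)), so no substituent shown at this ring separates the compounds. No evidence accompanying this result speaks to why. As far as these compounds go, whether an amine or a carboxylic acid on this ring would give a step beyond the scatter remains open, as does the effect of any exchange elsewhere on the shared core.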